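This account rests on a few compounds, and the source may have more. Where it says the series, first, only, none or still open, it means among the compounds named here.

Compounds measured so far in an assay on HepG2 cells for inhibition of 3-hydroxy-3-methylglutaryl-coenzyme A reductase (Homo sapiens); a lower number here means a stronger inhibitor, a higher number a weaker inhibitor:
- compound 1, `Cc1cc(-c2ccc(F)cc2)c(/C=C/[C@@H]2C[C@@H](O)CC(=O)O2)c(C(C)C)n1`: 50 nM
- compound 2, `CC(C)c1nc(C2CCCCC2)cc(-c2ccc(F)cc2)c1/C=C/[C@@H]1C[C@@H](O)CC(=O)O1`: 9.5 nM
- compound 3, `CC(C)c1nc(-c2ccc(F)cc2)cc(-c2ccc(F)cc2)c1/C=C/[C@@H]1C[C@@H](O)CC(=O)O1`: 7.5 nM

Compound 3 has the lowest number of the three, though one of its gaps is small (a 1.3-fold lower number from compound 2 to compound 3 (0.10 log units; within the scatter)), while the other is clear (a 6.7-fold lower number from compound 1 to compound 3 (0.82 log units; beyond the scatter)). Compound 4, `Cc1ccc(C)c(-c2cc(-c3ccc(F)cc3)c(/C=C/[C@@H]3C[C@@H](O)CC(=O)O3)c(C(C)C)n2)c1`, differs from compound 3 by 2,5-dimethylphenyl in place of 4-fluorophenyl on an aromatic carbon. The step that bears most directly on this change is a 1.3-fold lower number from compound 2 to compound 3 (0.10 log units; within the scatter), where swapping one ring group for another at the same place altered little; a 5.3-fold lower number from compound 1 to compound 2 (0.72 log units; beyond the scatter) and a 6.7-fold lower number from compound 1 to compound 3 (0.82 log units; beyond the scatter) show that ring groups in place of methyl there lowered the number. Compound 4 is therefore expected to change little, about a 1.3-fold higher number from compound 3 to compound 4 (0.12 log units; within the scatter). The estimate for compound 4 is 10 nM, within 3 nM to 35 nM.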

Compound 4, half-maximal inhibitory concentration: 20 nM
The estimate for compound 4 lay 2.0-fold (0.30 log units) below the measured number; low and high end bracket the measured number.
By their numbers in this assay, from the lowest: compounds 3 and 2 (each within the scatter of the next); then compound 4; then compound 1.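

Ring groups at this position are not interchangeable after all: 2,5-dimethylphenyl gives (a 2.7-fold higher number from compound 3 to compound 4 (0.43 log units; beyond the scatter)) and (a 2.1-fold higher number from compound 2 to compound 4 (0.32 log units; beyond the scatter)), whereas exchanging cyclohexyl for 4-fluorophenyl stayed within the scatter. It still improves on methyl (a 2.5-fold lower number from compound 1 to compound 4 (0.40 log units; beyond the scatter)), so a ring group of this kind keeps part of the gain. Nothing available explains the loss against the other two ring groups.

On these data alone, because this change both removes the fluorine and adds two methyl groups, their separate contributions remain open. Unsubstituted phenyl, a single methyl on the ring, or an amine there could begin to separate them.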